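Swapping Chloro for Fluoro in a Cytotoxicity Series

A few compounds are considered here, and "the series" means these few. Any claim that something is new, unique, unknown or untested is made for them only; others in the source may bear on it.

Compound 1 `C=CCn1c(=O)/c(=C\c2ccccc2Cl)[nH]c(=O)/c1=C\c1ccccc1OC` holds the higher of the two numbers reported in a functional assay on NCI-H1975 cells (Homo sapiens) for cytotoxicity, read by CCK-8 assay, with a stated time of 72 h; a lower number here means a stronger inhibitor, a higher number a weaker inhibitor; in this assay compound 1 gives 9200 nM. Compound 2 `COc1ccccc1/C=c1/[nH]c(=O)/c(=C\c2nc[nH]c2C(C)(C)C)[nH]c1=O` gives 100 nM in this assay, a far lower number, and the gap between the two lies well beyond the scatter of repeated measurements. Compound 3 `C=CCn1c(=O)/c(=C\c2cc(OC)c(OC)c(OC)c2)[nH]c(=O)/c1=C\c1cccc(Br)c1` was reported in this assay as "not active" (no number reported), without a number. Within the data shown here, no two of these three compounds differ in a single place, so no single step connects them.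

Compound 4 `C=CCn1c(=O)/c(=C\c2ccccc2F)[nH]c(=O)/c1=C\c1ccccc1OC` differs from compound 1 in one place: fluoro in place of chloro on an aromatic carbon. Everything else in the shared core of compound 1 stays the same. Among the measured compounds shown here, no measured pair shows this change, so its effect is not known from the data. An exchange of one halogen for another is expected to move this assay only a little, and the step of a 1.2-fold higher number from compound 1 to compound 4 (0.08 log units; within the scatter) is expected to stay within the scatter, with no clear direction. Compound 4 is therefore estimated at 11000 nM in this assay, with a range from 4000 nM to 35000 nM.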

Compound 4, half-maximal inhibitory concentration: 25100 nM
Compound 4: the middle estimate sits 2.3-fold (0.36 log units) below what was measured, and the stated range covers the measured number.
By their numbers in this assay, from the lowest: compound 2; then compound 1; then compound 4.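

Among these compounds, this is the first measured pair at this position, and it shows that the 2-chlorophenyl group of compound 1 and the 2-fluorophenyl group of compound 4 are not interchangeable in this assay: fluoro in place of chloro gives a 2.7-fold higher number from compound 1 to compound 4 (0.44 log units; beyond the scatter). The step is modest but lies beyond the scatter, so this place on a six-membered aromatic ring of carbon only, ortho to a large group, does register an exchange of one halogen for another, and compound 1 holds the lower number of the pair. Nothing among the data shown offers an explanation for the direction or the size of this step.

One pair cannot show whether the exchange of chloro for fluoro moves the number the same way when other groups stand elsewhere on the shared core. It also leaves open how a bromo, methyl, trifluoromethyl or nitrile group at this same place would compare with compound 1, and so whether any group here would bring the number lower.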